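This account rests on a few compounds, and the source may have more. Where it says the series, first, only, none or still open, it means among the compounds named here.

Measured compounds and their numbers in a functional assay on HEp-2 cells (Homo sapiens) for cytotoxicity, read by MTT assay, with a stated time of 72 h, tested at 10 ug/mL; on this read-out higher numbers stand for more inhibition of growth at the one concentration tested and lower numbers for less inhibition of growth: compound 1 `O=C1NC(=S)/C(=C/c2ccc(Cl)cc2)S1` gives 22.3%; compound 2 `O=C1NC(=S)/C(=C/c2cc(Cl)cc(Cl)c2Cl)S1` gives 23.5%; compound 3 `O=C1NC(=S)/C(=C/c2ccc(Cl)c(Cl)c2)S1` gives 16.4%.

All three share the same core and differ only in how many chloro groups sit on the aromatic ring. Compound 1 carries one chloro group. Its number lies between those of compound 2 and compound 3, but the gap to compound 2 is within the scatter, and the step of a number 5.9 percentage points lower from compound 1 to compound 3 (within the scatter) is within the scatter as well. On these numbers, adding a second chloro group to the ring of compound 1 did not move the read-out by more than the usual noise.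

Compound 4 `O=C1NC(=S)/C(=C/c2ccc(Cl)cc2Cl)S1` is the not yet measured member. It differs from compound 1 by chloro in place of hydrogen on an aromatic carbon. Among the measured compounds shown here, the only measured step that bears on this change is the one from compound 1 to compound 3, where a chloro group also replaced a hydrogen on the ring, and that step stayed within the scatter. Compound 2, with three chloro groups, also sits within the scatter of compound 1. No step beyond the scatter is therefore expected in this assay.

The expected step for compound 4 is a number 0.3 percentage points lower from compound 1 to compound 4 (within the scatter). For compound 4 the estimate is 22%, with a range from 12% to 32%.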

Compound 4, percent growth inhibition at one concentration: 24.8%
Beside the measured number, compound 4's estimate is 2.8 percentage points below it; measured number inside the range.
By their numbers in this assay, from the lowest: compounds 3, 1, 2 and 4 (each within the scatter of the next).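

In this assay, among the compounds shown here, compound 4 places its added chloro group ortho to a group of 8 heavy atoms and meta to a chloro group, a place on the aromatic ring not covered by the only earlier step of this kind, a number 5.9 percentage points lower from compound 1 to compound 3 (within the scatter). At this new place the change gives a number 2.5 percentage points higher from compound 1 to compound 4 (within the scatter), so the read-out shows no shift that can be told from noise. Across these two single changes, a second chloro group at either place on the ring of compound 1 leaves the number within the scatter, and no measurement shown here offers an explanation for this or bears on what the chloro group does at this position.

On these data alone, what a group other than chloro would do at this position remains open: an amine, a carboxylic acid or a methoxy group might or might not move the number beyond the scatter. Also open is how a compound with no chloro group on the ring would compare, since every compound shown carries at least one.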